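Methoxy for methyl on the benzyl group: working notes

The compounds below may be only part of what the source reports. "The series", "measured", "known", "first", "only" and "open" are said of these compounds alone.

- compound 1 `Cc1cc(C)cc(C(=O)N(CCCCCC(=O)Nc2ccccc2N)CC(=O)NC2CCCCC2)c1` gives 42000 nM 
- compound 2 `Cc1ccc(CNC(=O)CN(CCCCCC(=O)Nc2ccccc2N)C(=O)c2cc(C)cc(C)c2)cc1` gives 9800 nM 

Among the measured compounds shown here, in a functional assay on A2780 cells (Homo sapiens) for cytotoxicity, read by MTT assay, with a stated time of 72 h (on this read-out higher numbers stand for weaker inhibition and lower numbers for stronger inhibition), compound 2 stands lowest of the two measured compounds, with 9800 nM as the best number so far. The next compound, compound 3 `COc1ccc(CNC(=O)CN(CCCCCC(=O)Nc2ccccc2N)C(=O)c2cc(C)cc(C)c2)cc1`, keeps everything else and carries methoxy in place of methyl on an aromatic carbon, para to a large group, so that 4-methylbenzyl becomes 4-methoxybenzyl (methoxy in place of methyl on an aromatic carbon). For the measured compounds named here, the only measured step that bears on this is a 4.3-fold lower number from compound 1 to compound 2 (0.63 log units; beyond the scatter), where 4-methylbenzyl replaced cyclohexyl on an amide-type nitrogen. That step exchanged a whole group and stayed modest. Going by the values given here, the present change is much smaller, and no measured pair compares methyl with methoxy directly. In this assay, on these data alone, no step beyond the scatter is therefore expected, and the direction remains open. The expected change is a 1.1-fold lower number from compound 2 to compound 3 (0.04 log units; within the scatter), an estimate that stays small. For compound 3 the estimated value is 9000 nM, with an expected range from 4500 nM to 20000 nM.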

Compound 3, half-maximal inhibitory concentration: 24600 nM
Compound 3: the middle estimate sits 2.7-fold (0.44 log units) below what was measured, outside the stated range (above it).
By their numbers in this assay, from the lowest: compound 2; then compounds 3 and 1 (each within the scatter of the next).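

In this assay, among the compounds shown here, this position responds to a small exchange: a 2.5-fold higher number from compound 2 to compound 3 (0.40 log units; beyond the scatter), the first direct reading of methoxy against methyl on an aromatic carbon, para to a large group, and the modest step goes against methoxy. The advantage of 4-methylbenzyl over cyclohexyl therefore does not extend to 4-methoxybenzyl, as a 1.7-fold lower number from compound 1 to compound 3 (0.23 log units; within the scatter) leaves that pair within the scatter of each other, so a benzyl group alone does not secure the better number seen for compound 2. No available evidence explains the difference between methyl and methoxy here.

On these data alone, it remains open whether a fluorine, a hydroxyl or an ethyl group at the same place would read closer to compound 2 or to compound 3, and so whether methyl is a favourable case or methoxy an unfavourable one. Also open, as far as these compounds go, is whether the methoxy-for-methyl step keeps its direction and size with an amine or a carboxylic acid elsewhere on the benzyl ring, or with a longer chain in place of the benzyl linker.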